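The source may report more compounds than this note shows. Statements on the series, on what has been measured and on what is new or still open speak of the compounds shown alone.

Measured compounds in an ADME assay on cells (Homo sapiens) for cytotoxicity, read by resazurin assay, with a stated time of 5 days; a lower number here means that less compound is tolerated, a higher number that more compound is tolerated:

Compound 1 `O=S(=O)(Cc1nc(-c2ccncc2)c2sccc2n1)c1cccc(Cl)c1` gives > 50000 nM, a limit of the assay.
Compound 2 `COc1ccc(-c2nc(C[S+]([O-])c3cccc(Cl)c3)nc3ccsc23)cn1` gives > 50000 nM, a limit of the assay.
Compound 3 `COc1ccc(-c2nc(CSc3cccc(Cl)c3)nc3ccsc23)cn1` gives > 10000 nM, a limit of the assay.

Compound 1 stands at the upper limit of this assay, and no number has been obtained for it. The other two values are likewise limits: the limit of > 50000 nM in this assay, at which 2 of the 3 values shown sit, and (the limit of > 10000 nM in this assay, at which 1 of the 3 values shown sits). Going by the values given here, the only measured step, a step that the two limits leave unreadable from compound 2 to compound 3, is therefore unreadable, and it does not touch the part of compound 1 that is changed here.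

Compound 4 `O=S(=O)(Cc1nc(-c2ccc(F)nc2)c2sccc2n1)c1cccc(Cl)c1` differs from compound 1 in one place: 6-fluoropyridin-3-yl in place of pyridin-4-yl on an aromatic carbon. Among the compounds with values here, no measured step bears on this change. Within the data shown here, the only guide is that compound 1 and both other measured compounds sit at limits, so no cytotoxicity has been detected anywhere. The expectation for compound 4 is therefore a step that the limit leaves unreadable from compound 1 to compound 4, no change beyond the scatter, with the result again most likely a limit. Compound 4 is estimated at 60000 nM, with a range from 25000 nM to 200000 nM.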

Compound 4, half-maximal cytotoxic concentration: 40000 nM
Compound 4: middle estimate off by 1.5-fold (0.18 log units), on the high side; low and high end bracket the measured number.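

In this assay, compound 4 is the only compound shown that has a number rather than a limit, so cytotoxicity can be read at this position for the first time. Replacing pyridin-4-yl with 6-fluoropyridin-3-yl on the core gives an at least 1.2-fold lower number from compound 1 to compound 4 (0.09 log units; that floor lies within the scatter). The size of this step is known only as a floor, and no change beyond the scatter can be claimed, because compound 1 sits at a limit: the limit of > 50000 nM in this assay, at which 2 of the 4 values shown sit.

On these data alone, it remains open whether the fluorine or the change from a pyridin-4-yl to a pyridin-3-yl attachment accounts for the number, which a plain pyridin-3-yl at this position would separate. As far as these compounds go, how an amine or a carboxylic acid on this ring would read in this assay also remains open.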